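Fluoro for trifluoromethoxy at the cytotoxicity limit

The compounds below may be only part of what the source reports. "The series", "measured", "known", "first", "only" and "open" are said of these compounds alone.

In a functional assay on HepG2 cells (Homo sapiens) for cytotoxicity, with a stated time of 72 h (a lower number here means that less compound is needed, a higher number that more compound is needed for the effect), compound 1 `C=C[C@@](C)(/C=C/c1ccc(OS(=O)(=O)C(F)(F)F)cc1)CCC=C(C)C` gives > 52000 nM as a limit and not a number. Compound 2 `C=C[C@@](C)(/C=C/c1ccc(Nc2ccc(OC)cc2)cc1)CCC=C(C)C` gives > 52000 nM as a limit as well. Compound 3 `C=C[C@@](C)(/C=C/c1ccc(Nc2ccc(OC(F)(F)F)cc2)cc1)CCC=C(C)C` stands at > 52000 nM which is again only a limit. Among the compounds with values here, the series so far rests on the limit of > 52000 nM in this assay, at which 3 of the 3 values shown sit, and offers no numerical ranking. Compound 4 `C=C[C@@](C)(/C=C/c1ccc(Nc2ccc(F)cc2)cc1)CCC=C(C)C` has fluoro in place of trifluoromethoxy on an aromatic carbon. Within the data shown here, two measured steps bear on this change, a step that the two limits leave unreadable from compound 1 to compound 2 and a step that the two limits leave unreadable from compound 2 to compound 3 and neither gives a size to carry over. The expected step is a number no higher from compound 3 to compound 4 (the limit leaves the size open) with no direction and nothing beyond the scatter. For compound 4 the estimate is 52000 nM with an expected range of 25000 nM to 100000 nM and another limit reading is likely.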

Compound 4, half-maximal effective concentration: > 52000 nM
Compound 4 was reported as a limit; the forecaster's own chance of this, stated with the estimate: 80%; the middle value sits exactly at the limit.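

Compound 4 gives no readable step against compound 1, compound 2 or compound 3 in this assay, since all four stand at a limit and not a number: the limit of > 52000 nM in this assay, at which 4 of the 4 values shown sit.

From the compounds shown here alone, how fluoro, methoxy and trifluoromethoxy rank against one another in this assay stays open.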